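Formyl in Place of Vinyl on a Weakly Cytotoxic Core

The source may report more compounds than this note shows. Statements on the series, on what has been measured and on what is new or still open speak of the compounds shown alone.

Compound 1, `C=CCn1c(-c2ccc(OC)cc2C=C)cc2ccccc2c1=O`, was tested in a functional assay on SK-OV-3 cells (Homo sapiens) for cytotoxicity, read by MTT assay, with a stated time of 48 h (on this read-out higher numbers stand for weaker inhibition and lower numbers for stronger inhibition), where compound 1 gives 43800 nM. For the measured compounds named here, the only other measured compound, compound 2, `COCOCc1cc(OC)c(OC)cc1-c1cc2ccccc2c(=O)[nH]1`, gives in this assay 87700 nM. These two numbers lie within the usual scatter of repeated measurements of one another, so compound 1 is not set apart from compound 2 by the data at hand.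

Compound 3, `C=CCn1c(-c2ccc(OC)cc2C=O)cc2ccccc2c1=O`, has not yet been measured. It differs from compound 1 by formyl in place of vinyl on an aromatic carbon. Going by the values given here, no measured pair shows what such a change does on this core, so nothing beyond the scatter is expected: the step of a 1.0-fold lower number from compound 1 to compound 3 (0.02 log units; within the scatter) is estimated to stay within the usual scatter. Compound 3 is therefore expected to give about 42000 nM in this assay, in a range from 15000 nM to 120000 nM.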

Compound 3, half-maximal inhibitory concentration: 65500 nM
Compound 3: the middle estimate sits 1.6-fold (0.19 log units) below what was measured; the range from low to high includes it.
By their numbers in this assay, from the lowest: compounds 1, 3 and 2 (each within the scatter of the next).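

Putting formyl in place of vinyl on this aromatic carbon, ortho to a large group and meta to a methoxy group, gives a 1.5-fold higher number from compound 1 to compound 3 (0.17 log units; within the scatter) in this assay. For the compounds shown here, this is the first measured pair on the shared core, and it shows that this one change does not separate the two compounds on this read-out, even though formyl carries one hydrogen-bond acceptor and vinyl carries none. No measurement at hand offers an explanation for this result.

The pair leaves open whether a clearly different group at this position, such as an amine, a carboxylic acid or a longer chain, would move the number beyond the scatter. It also leaves open whether formyl in place of vinyl would behave the same way on another core.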